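This account rests on a few compounds, and the source may have more. Where it says the series, first, only, none or still open, it means among the compounds named here.

Compound 1: `Cc1ccc2c(c1)[n+]([O-])c(C(=O)NCc1ccccc1)c(C)[n+]2[O-]` — > 100 ug/mL
Compound 2: `Cc1cc2c(cc1C)[n+]([O-])c(C(=O)NCc1ccccc1)c(C)[n+]2[O-]` — "not determined" (no result reported)

The two measured compounds share one core and carry the same benzylamide side chain; they differ only in the methyl pattern on the carbon-only ring. The read-out is an ADME assay on Vero cells (Chlorocebus sabaeus) for cytotoxicity, read by MTT assay, with a stated time of 72 h; a higher number here means a weaker inhibitor, a lower number a stronger inhibitor. In this assay compound 1 gives > 100 ug/mL, which is a limit of the assay and not a number. For compound 2 this assay records "not determined" (no result reported), so nothing can be said about it. For the measured compounds named here, compound 1 therefore stands at the limit of > 100 ug/mL in this assay, at which 1 of the 2 values shown sits, and no step between measured compounds is available.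

Compound 3 is `Cc1c(C(=O)NCc2ccccc2)[n+]([O-])c2cc(Cl)ccc2[n+]1[O-]`. It differs from compound 1 by chloro in place of methyl on an aromatic carbon. Going by the values given here, with no measured step to lean on, the expectation rests on compound 1 alone: since that compound already sits at the limit, no step beyond the scatter is expected in either direction, and the step that the limit leaves unreadable from compound 1 to compound 3 is estimated to be small. Compound 3 is thus expected to give about 150 ug/mL, within a range from 70 ug/mL to 320 ug/mL, most likely again reported only as a limit.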

Compound 3, half-maximal inhibitory concentration: > 100 ug/mL
Compound 3: no number, only a limit; the forecaster's own chance of this, stated with the estimate: 85%; the middle value is on the limit's open side.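

In this assay compound 3 gives > 100 ug/mL, which is a limit of the assay and not a number. No step from compound 1 to compound 3 can be read, as both compounds stop at the same limit: the limit of > 100 ug/mL in this assay, at which 2 of the 3 values shown sit.

The compounds shown leave open whether chloro in place of methyl on an aromatic carbon changes the result in this assay at all.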